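A few compounds are considered here, and "the series" means these few. Any claim that something is new, unique, unknown or untested is made for them only; others in the source may bear on it.

Working notes on the series. Compound 2 `N[C@@H](COP(=O)(O)OCCCOC(=O)CCc1ccccc1OCc1cccc(OC2CCCCC2)c1)C(=O)O` is the point of departure. Among the compounds with values here, in an assay on cells for agonist activity at probable G-protein coupled receptor 34 (Mus musculus), with a stated time of 1 h (a higher number here means a larger maximal response, a lower number a smaller maximal response), compound 2 gives 18.8%, the higher of the two numbers obtained so far; its only neighbour is compound 1 `N[C@@H](COP(=O)(O)OCCCOC(=O)CCc1ccccc1OCc1cccc(Cc2ccccc2)c1)C(=O)O`, which in this assay gives 14.5%. Within the data shown here, the single step measured to date, a number 4.3 percentage points higher from compound 1 to compound 2 (within the scatter), lies within the scatter, so the two compounds are not separated by it.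

Compound 3 `Cc1ccc(Oc2cccc(COc3ccccc3CCC(=O)OCCCOP(=O)(O)OC[C@H](N)C(=O)O)c2)cc1` is the next member and is not yet measured. Its difference from compound 2 reads: 4-methylphenyl in place of cyclohexyl on an oxygen on an aromatic ring. Among the measured compounds shown here, the one measured step bears on this only loosely: there a benzyl on an aromatic carbon gave way to cyclohexyloxy without a shift beyond the scatter, and the present change instead puts an aromatic ring back onto the oxygen on the aromatic ring. Nothing in the two numbers points to a move beyond the scatter in this assay in either direction.

For compound 3 a largest response of about 17% is expected, with a range from 8% to 28%. The step of a number 1.8 percentage points lower from compound 2 to compound 3 (within the scatter) implied by this estimate is expected to be essentially flat.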

Compound 3, largest response reached (Emax), in percent of the reference or control that the assay uses: 18.2%
Compound 3: the middle estimate sits 1.2 percentage points below what was measured; low and high end bracket the measured number.
By their numbers in this assay, from the lowest: compounds 1, 3 and 2 (each within the scatter of the next).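

In this assay, the change from cyclohexyl to 4-methylphenyl on an oxygen on an aromatic ring gives a number 0.6 percentage points lower from compound 2 to compound 3 (within the scatter), so a non-aromatic and an aromatic six-membered ring are not separated at this place. The comparison with the benzyl group gives a number 3.7 percentage points higher from compound 1 to compound 3 (within the scatter), which adds a second step that stays within the scatter. Benzyl, cyclohexyloxy and 4-methylphenoxy therefore all lie within the scatter of one another, and none of these three groups stands apart in this assay. No measured data are available that could account for this flat picture.

The three groups shown contain only carbon beyond the linking oxygen, so it remains open whether an amine or a carboxylic acid at this place would move the largest response beyond the scatter. It is also open whether a much smaller group such as methoxy, or a longer chain such as n-hexyloxy, would do so, since the compounds shown do not define how far this place tolerates change.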